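Compound 1 to compound 4: anilino for dimethylamino

The source may hold more compounds than are shown below. What is called first, only, known or untested is meant among the compounds shown, and "the series" means these compounds.

Measured so far in a physicochemical assay for solubility, with a stated time of 24 h, at pH 4.5 (a lower number here means a less soluble compound, a higher number a more soluble compound), for three compounds:
compound 1 `COC(=O)c1ccc2ccc(C(=O)N(C)C)c-2cc1` gives 50 ug/mL as a number
compound 2 `CN(C)C(=O)c1c[nH]c2ccccc12` gives > 47 ug/mL as a limit
compound 3 `O=C(NCc1cccnc1)c1ccc2ccc(C(=O)c3ccccc3)c-2cc1` gives < 1 ug/mL as a limit

Compound 1 is the only one of the three with an actual number in this assay and so serves as the single reference point. The other two values are limits, so neither gives a measured distance from compound 1.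

Compound 4 `COC(=O)c1ccc2ccc(C(=O)Nc3ccccc3)c-2cc1` has anilino in place of dimethylamino on a carbonyl carbon. Among the measured compounds shown here, no measured pair isolates this change, so the expectation rests on thin evidence. A downward step beyond the usual scatter is expected in this assay all the same. For the measured compounds named here, the only guide is compound 3, which also has an aromatic ring on a carbonyl carbon and whose < 1 ug/mL is a limit. The expected size is a 6.3-fold lower number from compound 1 to compound 4 (0.80 log units; beyond the scatter) as an estimate. For compound 4 the estimated value is 8 ug/mL with an expected range of 1.5 ug/mL to 30 ug/mL in this reading.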

Compound 4, solubility: < 1 ug/mL
Compound 4 was reported as a limit; the forecaster's own chance of this, stated with the estimate: 15%; middle value at least 8.0-fold (0.90 log units) away from the limit.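

In this assay, the change on a carbonyl carbon now has its first measured single-change pair: anilino in place of dimethylamino gives an at least 50-fold lower number from compound 1 to compound 4 (1.69 log units; beyond the scatter). Compound 4 gives < 1 ug/mL, which is a limit and not a number. The step is therefore a bound, and its full size cannot be read, as compound 4 sits at the lower limit of the assay: the limit of < 1 ug/mL in this assay, at which 2 of the 4 values shown sit.

The compounds shown do not separate the aromatic ring of anilino from the amide hydrogen it brings, so it remains open which of the two goes with the step. Methylamino on the same carbonyl carbon would keep the amide hydrogen without the ring, and a methyl-capped anilino would keep the ring without that hydrogen.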